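The source may hold more compounds than are shown below. What is called first, only, known or untested is meant among the compounds shown, and "the series" means these compounds.

Compound 1 `CC(=O)Nc1cc(OCC(C)C)nc(SCc2ccccc2)n1`: 19900 nM
Compound 2 `CC(=O)Nc1cc(OCc2ccccc2)nc(SCc2ccccc2)n1`: 35200 nM
Compound 3 `CC(C)Cn1c(SCc2ccccc2)nc(N)cc1=O`: 83300 nM

These three compounds were tested in a functional assay on A549 cells (Homo sapiens) for antiproliferative activity, read by MTT assay, with a stated time of 72 h; on this read-out lower numbers stand for stronger inhibition of growth and higher numbers for weaker inhibition of growth. In this assay compound 1 gives 19900 nM, and compound 2 gives 35200 nM. Compound 2 differs from compound 1 in one place only: phenyl in place of isopropyl on a saturated chain carbon bound to an oxygen on an aromatic ring. This change produced a 1.8-fold higher number from compound 1 to compound 2 (0.25 log units; within the scatter).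

Compound 3 is built on a different core; how its core differs from that of compound 1 is not broken down here. Compound 4 `Nc1cc(=O)n(Cc2ccccc2)c(SCc2ccccc2)n1` has not yet been measured. It differs from compound 3 in one place: phenyl in place of isopropyl on a saturated chain carbon bound to an aromatic nitrogen. The place is not the same word for word as in the earlier pair, where the change sat on a saturated chain carbon bound to an oxygen on an aromatic ring, so this is the same kind of change, not the same change.

For compound 4 the expected step, a 1.4-fold higher number from compound 3 to compound 4 (0.16 log units; within the scatter), rests on the earlier step of the same kind being a 1.8-fold higher number from compound 1 to compound 2 (0.25 log units; within the scatter), a step within the scatter. Compound 4 is therefore estimated at 120000 nM, with a likely range from 50000 nM to 300000 nM.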

Compound 4, concentration for 50% growth inhibition: > 100000 nM
Compound 4 ended at the assay's limit (the forecaster's own chance of this, stated with the estimate: 25%); the middle value lies beyond the limit too.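

In this assay compound 4 gives > 100000 nM, which is a limit of the assay and not an exact number. The change from isobutyl to benzyl on the core of compound 3 can therefore be read only as a floor: an at least 1.2-fold higher number from compound 3 to compound 4 (0.07 log units; that floor lies within the scatter), and the true step may be larger. Both cores give no sign of stronger growth inhibition with the benzyl group, but this does not show that the change carries over from one core to the other with the same size: the same change on two cores in this assay, a 1.8-fold higher number (0.25 log units; within the scatter) from compound 1 to compound 2 and an at least 1.2-fold higher number (0.07 log units; that floor lies within the scatter) from compound 3 to compound 4; the limit leaves it open whether they differ

The compounds shown leave open how the growth inhibition would respond to other groups in these two places, such as an amine or a carboxylic acid at the end of the chain in place of the phenyl, or a longer chain. Among these compounds, with only two pairs carrying this change, and one of them ending at the limit, they also leave open whether any general rule holds across the series.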